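Dimethylamino in place of cyclopentylamino on the shared core

The source may hold more compounds than are shown below. What is called first, only, known or untested is meant among the compounds shown, and "the series" means these compounds.

Working notes on a small series measured in a functional assay for inhibition, with Rattus norvegicus as the target; a lower number here means a stronger inhibitor, a higher number a weaker inhibitor. Compound 1 `CCc1cc(Br)ccc1C/N=c1\c(O)c(O)\c1=N/C(C)(C)C` gives 270 nM in this assay. Compound 3 `CC(/N=c1\c(O)c(O)\c1=N/[C@H](C)C(C)(C)C)c1ccc(C#N)cc1` gives 6500 nM. Compound 2 `N#Cc1ccc(CNc2c(NC3CCCC3)c(=O)c2=O)cc1` gives 9400 nM, the highest number of the three; its value and that of compound 3 fall within the usual scatter of each other, whereas the gap from compound 2 to compound 1 lies beyond it, compound 1 being the stronger inhibitor of the pair.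

Compound 4 `CN(C)c1c(NCc2ccc(C#N)cc2)c(=O)c1=O` is not yet measured and differs from compound 2 in one place: dimethylamino in place of cyclopentylamino on an aromatic carbon. Going by the values given here, no pair of measured compounds differs in just this place, so no measured step sizes the change; compounds 1 and 3 differ from compound 2 in more than one place and give no direct guide. The change removes the one hydrogen-bond donor of the leaving group and keeps one acceptor. Compound 4 is therefore expected to stay near the weak end, with an estimate of 15000 nM, in the expected range 4000 nM to 50000 nM. The expected step of a 1.6-fold higher number from compound 2 to compound 4 (0.20 log units; within the scatter) is small, toward a weaker inhibitor, and may not clear the scatter.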

Compound 4, half-maximal inhibitory concentration: > 30000 nM
Compound 4: only a limit was reported; the forecaster's own chance of this, stated with the estimate: 15%; middle value at least 2.0-fold (0.30 log units) from the limit.
By their numbers in this assay, from the lowest: compound 1; then compounds 3 and 2 (each within the scatter of the next). At a limit, above all of these: compound 4.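

In this assay compound 4 gives > 30000 nM, which is a limit of the assay and not a number. Dimethylamino in place of cyclopentylamino on an aromatic carbon still yields a readable step, an at least 3.1-fold higher number from compound 2 to compound 4 (0.50 log units; beyond the scatter), the first single-place step in the series, and it shows that this position does not accept the change without a loss of inhibition. The full size of that loss stays unknown, as the step rests on a single limit: the limit of > 30000 nM in this assay, at which 1 of the 4 values shown sits.

The compounds shown leave open whether the loss follows the five-membered ring or the hydrogen-bond donor, since cyclopentylamino takes both with it when it leaves. Methylamino or pyrrolidin-1-yl on this same carbon would pull those two apart.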